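The source may report more compounds than this note shows. Statements on the series, on what has been measured and on what is new or still open speak of the compounds shown alone.

Among the compounds with values here, compound 1 `CCOC(=O)c1ccc(NC(=O)N2CC2C#N)cc1` is one of three compounds so far measured in a functional assay on L1210 cells (Mus musculus) for inhibition, read by MTT assay; a lower number here means a stronger inhibitor, a higher number a weaker inhibitor. In this assay compound 1 gives 9700 nM, the second highest of the three numbers. Compound 2 `N#CC1CN1C(=O)Nc1cccnc1` gives 11000 nM in this assay, a number within the scatter of that of compound 1, and compound 3 `N#CC1CN1C(=O)Nc1cccc2ccccc12` gives 7200 nM, also within the scatter of compound 1. The three numbers thus sit close together, with no gap between any two of them beyond the scatter.

Compound 4 `N#CC1CN1C(=O)Nc1ccccc1` has not yet been measured in this assay. It differs from compound 1 in one place: hydrogen in place of ethoxycarbonyl on an aromatic carbon. Within the data shown here, no pair of the measured compounds differs in a single place, so no measured step guides this change directly. Since compounds 1, 2 and 3, which differ from one another elsewhere in the structure, all give numbers within the scatter of each other, the step of a 1.0-fold lower number from compound 1 to compound 4 (0.01 log units; within the scatter) is expected to be small, in no direction beyond the scatter. Compound 4 is therefore estimated to give 9500 nM in this assay, within a range from 4500 nM to 20000 nM.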

Compound 4, half-maximal inhibitory concentration: 1200 nM
For compound 4 the middle estimate is 7.9-fold (0.90 log units) above the measured one; the whole stated range lies above it.
By their numbers in this assay, from the lowest: compound 4; then compounds 3, 1 and 2 (each within the scatter of the next).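

Within the data shown here, at this position the group carried matters in this assay: hydrogen in place of ethoxycarbonyl, on an aromatic carbon para to a group of 8 heavy atoms, brings an 8.1-fold lower number from compound 1 to compound 4 (0.91 log units; beyond the scatter) and gives the first single-place step. The earlier compounds shown here, whose numbers all lay within the scatter of one another, gave no sign that one change at one place could move the number beyond the scatter, and here the ethoxycarbonyl group proves unnecessary for reaching the lower number. Nothing at hand explains why this change lowers the number.

With only hydrogen and ethoxycarbonyl shown at this position, it remains open whether the step follows the size of the group or its kind. A methyl group, an amine or a carboxylic acid in the same place could separate these readings, and a shorter ester such as methoxycarbonyl could show whether the ester itself carries the difference.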